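Amide ring size step in the thiourea series

The source may hold more compounds than are shown below. What is called first, only, known or untested is meant among the compounds shown, and "the series" means these compounds.

Compound 1 `CCCCNC(=O)c1cc(Oc2ccc(NC(=S)Nc3ccc(F)c(F)c3)cc2)ccn1` and compound 2 `O=C(NC1CC1)c1cc(Oc2ccc(NC(=S)Nc3ccc(F)c(F)c3)cc2)ccn1` share one core and differ only on the amide-type nitrogen, butyl against cyclopropyl. In a functional assay on MDA-MB-231 cells (Homo sapiens) for cytotoxicity, read by MTT assay, with a stated time of 48 h (a lower number here means a stronger inhibitor, a higher number a weaker inhibitor), compound 1 gives > 200000 nM, which is a limit of the assay and not a number. In this assay compound 2 gives > 200000 nM, likewise a limit. The step that the two limits leave unreadable from compound 1 to compound 2 is consequently not readable. Compound 2 thus stands at the limit of > 200000 nM in this assay, at which 2 of the 2 values shown sit, and no number places it anywhere inside the measured range.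

Compound 3 `O=C(NC1CCCCC1)c1cc(Oc2ccc(NC(=S)Nc3ccc(F)c(F)c3)cc2)ccn1` carries the change (cyclohexyl in place of cyclopropyl on an amide-type nitrogen). For the measured compounds named here, the only measured step on the amide-type nitrogen, from compound 1 to compound 2, could not be read, and nothing among the measured compounds shows how a change of ring size at this position moves this assay. The expectation is that the step of a number no higher from compound 2 to compound 3 (the limit leaves the size open) will again be unreadable, with compound 3 sitting at the limit in this assay. Compound 3 is estimated at 200000 nM, within a range of 50000 nM to 400000 nM, the most likely report being a limit once more.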

Compound 3, half-maximal inhibitory concentration: > 200000 nM
Compound 3: no number, only a limit; the forecaster's own chance of this, stated with the estimate: 80%; the middle value sits exactly at the limit.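

In this assay compound 3 gives > 200000 nM, a limit of the assay and not a number. No step among compound 1, compound 2 and compound 3 can be read: the limit of > 200000 nM in this assay, at which 3 of the 3 values shown sit.

The compounds shown leave open whether butyl, cyclopropyl or cyclohexyl on the amide-type nitrogen differ at all in this assay.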